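This account rests on a few compounds, and the source may have more. Where it says the series, first, only, none or still open, it means among the compounds named here.

For the measured compounds named here, in a functional assay, read by Griess assay, with a stated time of 2.5 h (on this read-out lower numbers stand for stronger inhibition and higher numbers for weaker inhibition), only two compounds have numbers so far. Compound 1 (`COc1ccc(C(=O)/C=C/c2cc(OC)c(OC)cc2OC)cc1`) gives 2.07 ug/mL, and compound 2 (`COc1cc(OC)c(-c2cc(=O)c3ccc(O)cc3o2)cc1OC`) gives 2.27 ug/mL. Going by the values given here, these two values lie within the usual scatter of each other, so compound 1 cannot be separated from the only other compound measured. Compound 3 (`COc1cc(OC)c(OC)cc1/C=C/C(=O)c1cc(Cl)ccc1O`) has yet to be measured in this assay. Its structure departs from that of compound 1 at one place, on a carbonyl carbon whose other neighbours are a double-bonded chain carbon: 5-chloro-2-hydroxyphenyl in place of 4-methoxyphenyl on a carbonyl carbon. In words, 5-chloro-2-hydroxyphenyl stands in place of 4-methoxyphenyl. Among the compounds with values here, no measured pair of compounds differing in one place is available, so the data offer no direct guide to this change. With so little to go on, no step beyond the scatter is expected in this assay, and neither direction is favoured. The estimated change is a 1.2-fold higher number from compound 1 to compound 3 (0.08 log units; within the scatter). For compound 3 the expected value is 2.5 ug/mL, with an estimated range from 0.9 ug/mL to 7 ug/mL.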

Compound 3, half-maximal inhibitory concentration: 2.32 ug/mL
Compound 3: middle estimate off by 1.1-fold (0.03 log units), on the high side, within the range that was stated.
By their numbers in this assay, from the lowest: compounds 1, 2 and 3 (each within the scatter of the next).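

In this assay, putting 5-chloro-2-hydroxyphenyl in place of 4-methoxyphenyl on a carbonyl carbon gives a 1.1-fold higher number from compound 1 to compound 3 (0.05 log units; within the scatter), the first step read at this position. The entering group carries a hydrogen-bond donor that the leaving group lacks, as well as a chlorine, yet the two compounds have the same heavy-atom count and cannot be separated in this assay, so this exchange, taken as a whole, leaves no mark on the read-out beyond the usual scatter. No measurement is available that could explain this result.

Because the chlorine and the hydroxyl enter together, the compounds shown leave open what each would do alone, and whether one would move the number in a way that the other offsets. They also leave open whether this position would accept a very different substituent on a carbonyl carbon, such as a phenyl group bearing an amine or a carboxylic acid, with a step that likewise stays within the scatter.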